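Benzyl(methyl)amino to (4-Fluorophenyl)amino: Expectation Before Measurement

The compounds below may be only part of what the source reports. "The series", "measured", "known", "first", "only" and "open" are said of these compounds alone.

Compound 1 `Cc1cc(N2CCNCC2)nc(SCc2nc3ccccc3[nH]2)n1`: > 100000 nM
Compound 2 `Cc1cc(N(C)Cc2ccccc2)nc(SCc2nc3ccccc3[nH]2)n1`: > 100000 nM

In a functional assay on PC-3 cells (Homo sapiens) for cytotoxicity, read by MTT assay, with a stated time of 72 h (a lower number here means a stronger inhibitor, a higher number a weaker inhibitor), compound 1 gives > 100000 nM, which is a limit of the assay and not a number. Compound 2, carrying benzyl(methyl)amino in place of piperazin-1-yl on an aromatic carbon, gives > 100000 nM, likewise a limit. The step that the two limits leave unreadable from compound 1 to compound 2 is therefore unreadable, and compound 2 stands at the limit of > 100000 nM in this assay, at which 2 of the 2 values shown sit, with nothing shown on either side of it.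

Compound 3 `Cc1cc(Nc2ccc(F)cc2)nc(SCc2nc3ccccc3[nH]2)n1` differs from compound 2 by (4-fluorophenyl)amino in place of benzyl(methyl)amino on an aromatic carbon. Going by the values given here, the only measured step, a step that the two limits leave unreadable from compound 1 to compound 2, bears on this change merely by showing that two quite different substituents at this position both left the compound beyond the limit; no readable step size exists, so no direction or magnitude can be drawn from the measured compounds. The step of a number no higher from compound 2 to compound 3 (the limit leaves the size open) is expected to be none beyond the scatter, most likely ending again at a limit. Compound 3 is thus estimated at 100000 nM, within a range from 30000 nM to 300000 nM.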

Compound 3, half-maximal inhibitory concentration: 56200 nM
Beside the measured number, compound 3's estimate is 1.8-fold (0.25 log units) above it, and the stated range covers the measured number.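

In this assay compound 3 gives 56200 nM, the only one of the three compounds shown to return a number and not a limit of the assay, so this position can yield a readable value on the shared core. As far as these compounds go, the change to (4-fluorophenyl)amino reads as an at least 1.7-fold lower number from compound 2 to compound 3 (0.25 log units; that floor lies within the scatter), and the change from piperazin-1-yl reads as an at least 1.7-fold lower number from compound 1 to compound 3 (0.25 log units; that floor lies within the scatter); each floor lies within the scatter, so neither step establishes a real gain, and the true sizes stay open. The other two compounds remain at a limit: the limit of > 100000 nM in this assay, at which 2 of the 3 values shown sit.

The compounds shown leave open which part of the change matters, as the entering group differs from benzyl(methyl)amino in having a hydrogen-bond donor, a fluorine and a ring set directly on the nitrogen, and a single pair cannot separate these. A plain phenylamino group would speak to the fluorine, while benzylamino and N-methyl-(4-fluorophenyl)amino groups would speak to the nitrogen hydrogen and the link to the ring.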